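Allyl to Ethynyl on a Biaryl Amide

The source may report more compounds than this note shows. Statements on the series, on what has been measured and on what is new or still open speak of the compounds shown alone.

Compound 1 `COc1ccc(-c2ccc(C(S)=N[C@H](C)CCCc3cccnc3)cc2)cc1OC`: 60 nM in an assay (Canis lupus familiaris) for binding affinity to platelet-activating factor receptor (Homo sapiens), read by radioligand binding; on this read-out higher numbers stand for weaker inhibition and lower numbers for stronger inhibition
Compound 2 `C=CCc1cc(C(=O)N[C@H](C)CCCc2cccnc2)ccc1-c1ccc(OC)c(OC)c1`: 80 nM in this assay

Of the compounds shown here, two have been measured. In this assay compound 1 gives 60 nM and compound 2 gives 80 nM. Compound 2 holds the higher of the two numbers, and its nearest neighbour is compound 1, but the gap between them lies within the scatter of repeated measurements, so the two values show no real separation. Among the measured compounds shown here, compounds 1 and 2 differ in more than one place, and no single step joins them.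

Compound 3 `C#Cc1cc(C(=O)N[C@H](C)CCCc2cccnc2)ccc1-c1ccc(OC)c(OC)c1` is not yet measured. It differs from compound 2 in one place: ethynyl in place of allyl on an aromatic carbon. No measured step of this kind exists among the compounds shown, and no direction can be read from them. The change from compound 2 to compound 3 is expected to stay within the scatter, neither clearly stronger nor weaker, as expressed by no change at the digits printed from compound 2 to compound 3 (within the scatter). Compound 3 is therefore estimated at 80 nM, with an expected range from 30 nM to 250 nM.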

Compound 3, half-maximal inhibitory concentration: 5 nM
Beside the measured number, compound 3's estimate is 16-fold (1.20 log units) above it; measured number below the stated range.
By their numbers in this assay, from the lowest: compound 3; then compounds 1 and 2 (each within the scatter of the next).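

Ethynyl in place of allyl on this aromatic carbon, ortho to a 3,4-dimethoxyphenyl group, gives a 16-fold lower number from compound 2 to compound 3 (1.20 log units; beyond the scatter) in this assay and shows that the reading at this position depends strongly on the group it carries. The change is small in its counts: one carbon fewer and a triple bond for a double bond, with no ring, hydrogen-bond donor, hydrogen-bond acceptor or net charge on either group. Nothing available explains the size of this step.

Going by these compounds, how a nitrile, an ethyl or a propynyl group would read at this position remains open, so the triple bond cannot yet be separated from the shorter chain. Whether ethynyl would bring a step of similar size on the core of compound 1 is also unknown.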